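Sulfur substituent variation in a TRPV1 antagonist series

The source may report more compounds than this note shows. Statements on the series, on what has been measured and on what is new or still open speak of the compounds shown alone.

Measured compounds, with their values in an assay on CHO-K1 cells for antagonist activity at transient receptor potential cation channel subfamily V member 1 (Homo sapiens), read by FLIPR; on this read-out lower numbers stand for stronger inhibition and higher numbers for weaker inhibition:
- compound 1, `CCCCCSc1nc(C(F)(F)F)ccc1CNC(=O)C(C)c1ccc(NS(C)(=O)=O)c(F)c1`: compound 1 gives 95.6 nM
- compound 2, `CC(C(=O)NCc1ccc(C(F)(F)F)nc1SCCCN1CCCCC1)c1ccc(NS(C)(=O)=O)c(F)c1`: compound 2 gives 250 nM
- compound 3, `CC1CCC(Sc2nc(C(F)(F)F)ccc2CNC(=O)C(C)c2ccc(NS(C)(=O)=O)c(F)c2)CC1`: compound 3 gives 180 nM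

In this assay, among the measured compounds shown here, compound 3 is separated from compound 1 by a 1.9-fold higher number from compound 1 to compound 3 (0.27 log units; within the scatter) and from compound 2 by a 1.4-fold lower number from compound 2 to compound 3 (0.14 log units; within the scatter); neither gap exceeds the scatter, so the three numbers sit close together, with only the step of a 2.6-fold higher number from compound 1 to compound 2 (0.42 log units; beyond the scatter) reaching beyond it.

Compound 4, `CC(C(=O)NCc1ccc(C(F)(F)F)nc1SCc1ccc(Cl)cc1)c1ccc(NS(C)(=O)=O)c(F)c1`, has not been measured in this assay. It differs from compound 3 in one place: 4-chlorobenzyl in place of 4-methylcyclohexyl on a sulfur. For the measured compounds named here, the steps that bear on this are the two earlier exchanges on the same sulfur, a 1.9-fold higher number from compound 1 to compound 3 (0.27 log units; within the scatter) and a 1.4-fold lower number from compound 2 to compound 3 (0.14 log units; within the scatter), both within the scatter, and a 2.6-fold higher number from compound 1 to compound 2 (0.42 log units; beyond the scatter), which is modest. Going by the values given here, every substituent tried on this sulfur so far has given a number in a narrow band, and no aromatic group has yet been tested there. Accordingly the expectation for compound 4 is a step of a 1.2-fold lower number from compound 3 to compound 4 (0.08 log units; within the scatter), not beyond the scatter in either direction. Compound 4 is estimated at 150 nM, with a range from 55 nM to 420 nM.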

Compound 4, half-maximal inhibitory concentration: 674 nM
The estimate for compound 4 lay 4.5-fold (0.65 log units) below the measured number; measured number above the stated range.
By their numbers in this assay, from the lowest: compounds 1, 3 and 2 (each within the scatter of the next, the first and the last beyond it); then compound 4.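

In this assay, among the compounds shown here, 4-chlorobenzyl is the first group on this sulfur to stand clear of all the others: a 3.7-fold higher number from compound 3 to compound 4 (0.57 log units; beyond the scatter), a 2.7-fold higher number from compound 2 to compound 4 (0.43 log units; beyond the scatter) and a 7.1-fold higher number from compound 1 to compound 4 (0.85 log units; beyond the scatter), so compound 4 is the weakest of the four. The position therefore responds to the choice of substituent more than the earlier, closely spaced numbers suggested. The exchange of 4-methylcyclohexyl for 4-chlorobenzyl leaves the counts of hydrogen-bond donors, hydrogen-bond acceptors and net charge unchanged, and compound 4 is the only one shown with an aromatic ring in this substituent, a single example and no pattern.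

Nothing at hand accounts for the rise in the number. An unsubstituted benzyl group on the sulfur would show whether the chlorine or the aromatic ring goes with it.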